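The source may report more compounds than this note shows. Statements on the series, on what has been measured and on what is new or still open speak of the compounds shown alone.

In a functional assay on HCT-116 cells (Homo sapiens) for antiproliferative activity, read by sulforhodamine B assay, with a stated time of 72 h (on this read-out lower numbers stand for stronger inhibition and higher numbers for weaker inhibition), compound 1 `CSc1ccc(Nc2ncnc3c2ncn3[C@@H]2O[C@H](CO)[C@@H](O)[C@H]2O)cc1` shows > 100000 nM, which is a limit and not a number. Within the data shown here, compound 2 `CC(C)c1ccc(Nc2ncnc3c2ncn3[C@@H]2O[C@H](CO)[C@@H](O)[C@H]2O)cc1` gives 10000 nM, the only true number so far. Among the measured compounds shown here, the one measured step, an at least 10-fold lower number from compound 1 to compound 2 (1.00 log units; beyond the scatter), has isopropyl in place of methylsulfanyl on an aromatic carbon. Compound 3 `OC[C@H]1O[C@@H](n2cnc3c(NCCC4=CCCCC4)ncnc32)[C@H](O)[C@@H]1O` swaps a whole group instead: 2-(cyclohex-1-en-1-yl)ethyl in place of 4-isopropylphenyl on a nitrogen on an aromatic ring, on a nitrogen on an aromatic ring. That step from compound 1 touches only part of the leaving group, so it shows that this region matters but gives no direction here. The expected change is no change at the digits printed from compound 2 to compound 3 (within the scatter), with no shift beyond the scatter anticipated. For compound 3 the estimate is 10000 nM, with an expected range from 2000 nM to 60000 nM.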

Compound 3, half-maximal inhibitory concentration: 6000 nM
Beside the measured number, compound 3's estimate is 1.7-fold (0.22 log units) above it; low and high end bracket the measured number.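

Placing 2-(cyclohex-1-en-1-yl)ethyl on this nitrogen in place of 4-isopropylphenyl gives a 1.7-fold lower number from compound 2 to compound 3 (0.22 log units; within the scatter), so an aromatic ring at this position is not required to keep this level of activity. Placing the same group there in place of 4-(methylsulfanyl)phenyl gives an at least 16-fold lower number from compound 1 to compound 3 (1.22 log units; beyond the scatter). Compound 1 stands at a limit and not at a true number: the limit of > 100000 nM in this assay, at which 1 of the 3 values shown sits.

The compounds shown leave open how a saturated 2-cyclohexylethyl group or a straight hexyl chain on this nitrogen would compare. They also leave open whether the ring double bond contributes at all.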